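Amide nitrogen aryl swap in the furan-carboxamide series

The source may hold more compounds than are shown below. What is called first, only, known or untested is meant among the compounds shown, and "the series" means these compounds.

Measured compounds, with their values in an assay on T47D cells for inhibition of 17-beta-hydroxysteroid dehydrogenase type 1 (Homo sapiens), read by HPLC, with a stated time of 24 h; on this read-out higher numbers stand for weaker inhibition and lower numbers for stronger inhibition:
compound 1 `Cc1ccccc1N(C)C(=O)c1ccc(-c2ccc(O)cc2Cl)o1` gives 14 nM
compound 2 `Cc1ccccc1N(C)C(=O)c1ccc(-c2ccc(O)cc2F)o1` gives 10 nM
compound 3 `Cc1ccc(F)cc1N(C)C(=O)c1ccc(-c2ccc(O)cc2)o1` gives 12 nM

Compound 3 holds the second highest of the three numbers in this assay; its nearest neighbour is compound 1 and its furthest is compound 2, and neither gap reaches beyond the usual scatter. For the measured compounds named here, the only step measured so far, a 1.4-fold lower number from compound 1 to compound 2 (0.15 log units; within the scatter), concerns the ring that carries the hydroxyl and says nothing about the group on the amide nitrogen.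

Compound 4 `Cc1cccnc1N(C)C(=O)c1ccc(-c2ccc(O)cc2)o1` differs from compound 3 by 3-methylpyridin-2-yl in place of 5-fluoro-2-methylphenyl on an amide-type nitrogen. Going by the values given here, no measured pair changes this position, so there is no direct precedent. The three compounds together show that small changes on either aromatic ring have not moved the number in this assay beyond the scatter, and on that basis a step of a 1.3-fold higher number from compound 3 to compound 4 (0.10 log units; within the scatter) is expected, that is, no change beyond the scatter. For compound 4 the estimate in this assay is 15 nM, with a range from 5 nM to 45 nM.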

Compound 4, half-maximal inhibitory concentration: 1100 nM
The estimate for compound 4 lay 73-fold (1.87 log units) below the measured number; the measured number lies above the stated range.
By their numbers in this assay, from the lowest: compounds 2, 3 and 1 (each within the scatter of the next); then compound 4.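

The group on the amide nitrogen is not tolerant of every small change: in this assay the swap to 3-methylpyridin-2-yl gives a 92-fold higher number from compound 3 to compound 4 (1.96 log units; beyond the scatter) and is the only step shown at this position. For the compounds shown here, the one earlier step, on the ring that carries the hydroxyl, stayed within the scatter, so the amide nitrogen group is the first place where a single change moves the number beyond it. No measurement at hand bears on the cause of this step.

The swap removes the fluoro and brings in the ring nitrogen together, and the compounds shown do not separate these two changes. Also open, going by these compounds, is how this assay would read with an amine or a carboxylic acid on the ring at this position.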